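This account rests on a few compounds, and the source may have more. Where it says the series, first, only, none or still open, it means among the compounds named here.

Measured in a physicochemical assay for solubility, read by nephelometry, in phosphate buffer, measured as kinetic solubility, with a stated time of 30 min, at pH 6.5; a lower number here means a less soluble compound, a higher number a more soluble compound:
Compound 1 `O=C(O)COc1ccc([C@H]2CC[C@]3(CC2)OOC2(O3)C3CC4CC(C3)CC2C4)cc1`: < 1.6 ug/mL
Compound 2 `CC(C)(Oc1ccc([C@H]2CC[C@]3(CC2)OOC2(O3)C3CC4CC(C3)CC2C4)cc1)C(=O)O`: < 1.6 ug/mL
Compound 3 `CS(=O)(=O)NC(=O)COc1ccc([C@H]2CC[C@]3(CC2)OOC2(O3)C3CC4CC(C3)CC2C4)cc1`: < 1.6 ug/mL

Each of these entries is a limit of the assay and not a number. Compound 3 stands at its limit of < 1.6 ug/mL, so its true solubility is not known. The shared picture is the limit of < 1.6 ug/mL in this assay, at which 3 of the 3 values shown sit.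

Compound 4 `O=C(O)CCCOc1ccc([C@H]2CC[C@]3(CC2)OOC2(O3)C3CC4CC(C3)CC2C4)cc1` differs from compound 3 as follows: 2-carboxyethyl in place of (methylsulfonyl)carbamoyl on a saturated chain carbon bound to an oxygen on an aromatic ring. In words, 2-carboxyethyl stands in place of (methylsulfonyl)carbamoyl on a saturated chain carbon bound to an oxygen on an aromatic ring.

Going by the values given here, three measured steps bear on this change. The end group changes in a step that the two limits leave unreadable from compound 1 to compound 3, the chain and end group together in a step that the two limits leave unreadable from compound 2 to compound 3, and the chain alone in a step that the two limits leave unreadable from compound 1 to compound 2. None of them has a size that can be carried over. In this assay no step beyond the scatter is therefore expected, and a further limit is the likeliest report. The expected step is a step that the limit leaves unreadable from compound 3 to compound 4. The estimate for compound 4 is 1.2 ug/mL, with an expected range from 0.6 ug/mL to 3.2 ug/mL.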

Compound 4, solubility: < 3.1 ug/mL
Compound 4 was reported as a limit; the forecaster's own chance of this, stated with the estimate: 85%; the middle value lies beyond the limit too.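

Compound 4 gives < 3.1 ug/mL, which is a limit and not a number. Going by these compounds alone, compound 1, compound 2 and compound 3 also stand at limits, and no step from any of them to compound 4 can be read. As far as these compounds go, the true solubility of all four compounds remains open, as does whether their side chains separate them at all.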